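Chloro in place of methyl on a pyridinyl group

The compounds below may be only part of what the source reports. "The series", "measured", "known", "first", "only" and "open" are said of these compounds alone.

Among the measured compounds shown here, in a functional assay on HOS-TE85 cells (Homo sapiens) for inhibition, read by CCK-8 assay, with a stated time of 72 h (on this read-out lower numbers stand for stronger inhibition and higher numbers for weaker inhibition), compound 2 `Cc1ccnc(N2C(=O)CSC2c2cccc(C(=O)NCCCCn3cccn3)c2)c1` gives 19.6 nM, the lower of the two numbers so far, while compound 1 `COc1ccccc1N1C(=O)CSC1c1cccc(C(=O)NCCCCn2cccn2)c1` gives 91.7 nM. Compound 3 `O=C(NCCCCn1cccn1)c1cccc(C2SCC(=O)N2c2cc(Cl)ccn2)c1` differs from compound 2 in one place: chloro in place of methyl on an aromatic carbon, so 4-methylpyridin-2-yl becomes 4-chloropyridin-2-yl. For the measured compounds named here, the only measured step, a 4.7-fold lower number from compound 1 to compound 2 (0.67 log units; beyond the scatter), exchanged 2-methoxyphenyl for 4-methylpyridin-2-yl, a much larger change, so it offers little guidance here. Going by the values given here, no measured step covers chloro in place of methyl. The expected step in this assay is a 1.1-fold lower number from compound 2 to compound 3 (0.04 log units; within the scatter), none beyond the scatter. Compound 3 is estimated at 18 nM, with an expected range of 7 nM to 45 nM.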

Compound 3, half-maximal inhibitory concentration: 36.4 nM
Estimate against measurement, compound 3: 2.0-fold (0.31 log units) below, within the range that was stated.
By their numbers in this assay, from the lowest: compounds 2 and 3 (each within the scatter of the next); then compound 1.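

In this assay, the change at this carbon, opposite the ring nitrogen, gives a 1.9-fold higher number from compound 2 to compound 3 (0.27 log units; within the scatter), so methyl and chloro cannot be told apart here. The 4-chloropyridin-2-yl group also keeps a clear edge over 2-methoxyphenyl, with a 2.5-fold lower number from compound 1 to compound 3 (0.40 log units; beyond the scatter), so that edge does not rest on the methyl alone. Nothing available explains these numbers. Still open, from the compounds shown here alone, is whether an amine or a carboxylic acid at this same carbon would fit this pattern or break it.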